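Substituent on the carbonyl-bound oxygen: maximal response notes

The compounds below may be only part of what the source reports. "The series", "measured", "known", "first", "only" and "open" are said of these compounds alone.

Measured so far in a functional assay on isolated protein for agonist activity at Glucose-dependent insulinotropic receptor (Homo sapiens), read by HTRF and cAMP accumulation; a higher number here means a larger maximal response, a lower number a smaller maximal response:
compound 1 `CC(C)(C)OC(=O)N1CCC(O[C@H]2CC[C@H](Oc3cnc(S(C)(=O)=O)cn3)CC2)CC1` gives 110%
compound 2 `CC(C)OC(=O)N1CCC(O[C@H]2CC[C@H](Oc3cnc(S(C)(=O)=O)cn3)CC2)CC1` gives 110%
compound 3 `CS(=O)(=O)c1cnc(O[C@H]2CC[C@H](OC3CCN(C(=O)OC4CCOC4)CC3)CC2)cn1` gives 105%

Compound 3 holds the lowest of the three numbers, but the spread is small: a number 5 percentage points lower from compound 1 to compound 3 (within the scatter) and a number 5 percentage points lower from compound 2 to compound 3 (within the scatter), so none of the three is set apart from the others. The change from compound 1 to compound 2, hydrogen in place of methyl, also left the read-out flat: no change at the digits printed from compound 1 to compound 2 (within the scatter).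

Compound 4 `CS(=O)(=O)c1cnc(O[C@H]2CC[C@H](OC3CCN(C(=O)Oc4ccccc4)CC3)CC2)cn1` carries a different group on the same oxygen: phenyl in place of oxolan-3-yl on an oxygen next to a carbonyl group. The three measured steps all bear on this position, and each stayed inside the scatter, whether the group grew, shrank or gained a ring with a hetero atom. The entering phenyl is another group of similar size at that oxygen, so no step beyond the scatter is expected in this assay; the estimated step is no change at the digits printed from compound 3 to compound 4 (within the scatter). Compound 4 is therefore expected to give about 105%, with a range from 95% to 115%.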

Compound 4, largest response reached (Emax), in percent of the reference or control that the assay uses: 116%
Compound 4: middle estimate off by 11 percentage points, on the low side; the measured number lies above the stated range.
By their numbers in this assay, from the lowest: compounds 3, 1, 2 and 4 (each within the scatter of the next, the first and the last beyond it).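

For the compounds shown here, the step of a number 11 percentage points higher from compound 3 to compound 4 (beyond the scatter) in this assay is the first at this oxygen next to a carbonyl group to pass the scatter, so the position is not entirely flat for this read-out. Phenyl does not separate from isopropyl or tert-butyl, however: a number 6 percentage points higher from compound 2 to compound 4 (within the scatter) and a number 6 percentage points higher from compound 1 to compound 4 (within the scatter) both stay small. The one separation shown is therefore between two ring groups, the six-membered aromatic ring of carbon only and the five-membered non-aromatic oxolan-3-yl ring.

From the compounds shown here alone, whether a benzyl group, or a phenyl ring carrying a methoxy group or a chlorine atom, on the same oxygen would sit with compound 4 or with compound 3 stays open. Nothing available on this series accounts for the difference between phenyl and oxolan-3-yl.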